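Removing One Chloro from a Cytotoxic Compound

A few compounds are considered here, and "the series" means these few. Any claim that something is new, unique, unknown or untested is made for them only; others in the source may bear on it.

Compound 1 `COc1ccccc1/C=c1/[nH]c(=O)/c(=C\c2ccccc2OC)n(C)c1=O` gives "not active" (no number reported)
Compound 2 `COc1ccccc1/C=c1\c(=O)[nH]/c(=C/c2cccc(Cl)c2Cl)c(=O)n1C` gives 300 nM

Among the compounds with values here, in a functional assay on BGC-823 cells (Homo sapiens) for cytotoxicity, read by CCK-8 assay, with a stated time of 72 h (on this read-out higher numbers stand for weaker inhibition and lower numbers for stronger inhibition), compound 2 (300 nM) holds the only number so far, so it can be ranked against no other measured value. Compound 3 `COc1ccccc1/C=c1\c(=O)[nH]/c(=C/c2ccccc2Cl)c(=O)n1C` differs from it by hydrogen in place of chloro on an aromatic carbon with hydrogen in place of chloro on an aromatic carbon, turning 2,3-dichlorophenyl to 2-chlorophenyl. Within the data shown here, no measured pair shows this change alone. Compound 1 ("not active" (no number reported)) has no chloro group, which gives a weak hint that losing one may weaken inhibition. The expected 2.7-fold higher number from compound 2 to compound 3 (0.43 log units; beyond the scatter) is a modest weakening, somewhat beyond the usual scatter. Compound 3 is expected near 800 nM in this assay (estimated range 200 nM to 4000 nM).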

Compound 3, half-maximal inhibitory concentration: 300 nM
The estimate for compound 3 lay 2.7-fold (0.43 log units) above the measured number; the measured number falls inside the stated range.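

In this assay, putting hydrogen in place of chloro on this aromatic carbon gives no change at the digits printed from compound 2 to compound 3 (within the scatter) and turns 2,3-dichlorophenyl into 2-chlorophenyl. This chloro can therefore leave without a measurable loss of inhibition in these cells, at least with the rest of compound 3 unchanged. Nothing in the data explains this tolerance.

From the compounds shown here alone, whether the chloro that remains on the 2-chlorophenyl group is needed stays open. So does whether a larger or charged group at the vacated place, such as an amine or a carboxylic acid, would be accepted as well as hydrogen.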